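A few compounds are considered here, and "the series" means these few. Any claim that something is new, unique, unknown or untested is made for them only; others in the source may bear on it.

Working notes on the series. All compounds share one core and differ in the substituted phenyl on an amine nitrogen in a ring. In a functional assay on DU-145 cells (Homo sapiens) for inhibition, read by MTT assay, with a stated time of 72 h (on this read-out higher numbers stand for weaker inhibition and lower numbers for stronger inhibition), compound 1 (`O=C1C=C(N2CCN(c3ccc(F)cc3)CC2)C(=O)c2ccccc21`) gives 11700 nM, compound 2 (`O=C1C=C(N2CCN(c3ccccc3Cl)CC2)C(=O)c2ccccc21`) gives 2900 nM and compound 3 (`Cc1cccc(N2CCN(C3=CC(=O)c4ccccc4C3=O)CC2)c1`) gives 7400 nM. Two steps place that last value: a 1.6-fold lower number from compound 1 to compound 3 (0.20 log units; within the scatter), and a 2.6-fold higher number from compound 2 to compound 3 (0.41 log units; beyond the scatter).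

The next compound is compound 4 (`O=C1C=C(N2CCN(c3ccc(F)c(Cl)c3)CC2)C(=O)c2ccccc21`), still unmeasured. The change is 3-chloro-4-fluorophenyl in place of 3-methylphenyl on an amine nitrogen in a ring. For the measured compounds named here, no measured step makes this exact change. The nearest evidence is a 4.0-fold lower number from compound 1 to compound 2 (0.61 log units; beyond the scatter), which links the two groups that resemble the entering one. Whether their features combine cannot be read from three compounds, so a small step to a lower number is expected in this assay, probably within the scatter.

The estimated step is a 1.3-fold lower number from compound 3 to compound 4 (0.13 log units; within the scatter). For compound 4 the expected value is 5500 nM, with an estimated range of 2200 nM to 13000 nM.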

Compound 4, half-maximal inhibitory concentration: 32200 nM
Beside the measured number, compound 4's estimate is 5.9-fold (0.77 log units) below it, and the stated range ends below it.
By their numbers in this assay, from the lowest: compound 2; then compounds 3 and 1 (each within the scatter of the next); then compound 4.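

For the compounds shown here, replacing hydrogen with chloro on an aromatic carbon of the 4-fluorophenyl group gives a 2.8-fold higher number from compound 1 to compound 4 (0.44 log units; beyond the scatter) in this assay, the only step that adds one atom to an otherwise unchanged phenyl group. The 3-chloro-4-fluorophenyl group also shows a 4.4-fold higher number from compound 3 to compound 4 (0.64 log units; beyond the scatter) and an 11-fold higher number from compound 2 to compound 4 (1.05 log units; beyond the scatter), so on this amine nitrogen in a ring a chloro substituent goes with the lowest number in compound 2 and the highest in compound 4, and its presence alone does not set the direction of the change. No measurement shown accounts for these steps.

Open, on these data alone, is whether a 3-chlorophenyl group without the fluoro would stand nearer compound 1 or compound 4. Also open, as far as these compounds go, is whether a 2-methoxyphenyl or 2-methylphenyl group would stand near compound 2.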